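Trifluoromethyl for methyl on the cyano compound

The compounds below may be only part of what the source reports. "The series", "measured", "known", "first", "only" and "open" are said of these compounds alone.

In a functional assay on MCF7 cells (Homo sapiens) for antiproliferative activity, with a stated time of 96 h (a lower number here means a stronger inhibitor, a higher number a weaker inhibitor), compound 1 `Cc1cc(=O)oc2cc(OCC(=O)c3ccc(F)cc3)ccc12` gives > 100000 nM, which is a limit and not a number. Compound 2 `Cc1cc(=O)oc2cc(OCC(=O)c3ccc(C#N)cc3)ccc12` gives > 100000 nM, again only a limit. Compound 3 `Cc1cc(=O)oc2cc(OCC(=O)c3ccc(OC(F)(F)F)cc3)ccc12` gives > 100000 nM, likewise a limit. Compound 2 therefore has no readable value, and the whole picture so far is the limit of > 100000 nM in this assay, at which 3 of the 3 values shown sit.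

Compound 4 `N#Cc1ccc(C(=O)COc2ccc3c(C(F)(F)F)cc(=O)oc3c2)cc1` differs from compound 2 by trifluoromethyl in place of methyl on an aromatic carbon. In words, this is trifluoromethyl in place of methyl on an aromatic carbon, opposite the ring oxygen.

Three measured steps exist: a step that the two limits leave unreadable from compound 1 to compound 2, a step that the two limits leave unreadable from compound 1 to compound 3 and a step that the two limits leave unreadable from compound 2 to compound 3. Each exchanges one substituent for another on an aromatic carbon, none touches the methyl, and none has a readable size. They offer no measure for the present change. Within the data shown here, they show only that all three methyl compounds sit at the limit, and no compound goes against this.

In this assay the likeliest expectation is that compound 4 also reports only a limit. The estimated shift is an at least 1.4-fold lower number from compound 2 to compound 4 (0.15 log units; that floor lies within the scatter), toward stronger inhibition if a number appears at all, and its size is poorly fixed. For compound 4 the expected value is 70000 nM, with an estimated range from 15000 nM to 150000 nM.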

Compound 4, half-maximal inhibitory concentration: "not active" (no number reported)
No number was reported for compound 4, and the estimate cannot be compared.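

No new step can be read between compound 2 and compound 4, as compound 4 is reported as not active, with no number. In this assay compound 2 gives > 100000 nM, a limit and not a number. The compounds shown leave open whether trifluoromethyl in place of methyl shifts antiproliferative activity at all, with no numerical value available on which to judge it: the limit of > 100000 nM in this assay, at which 3 of the 4 values shown sit.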